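The compounds below may be only part of what the source reports. "The series", "measured", "known", "first", "only" and "open" are said of these compounds alone.

Measured compounds:
compound 1 `CN(C)CCCCNc1nc2cc([N+](=O)[O-])ccc2nc1NCc1ccc(C(F)(F)F)cc1` gives 9.73 ug/mL
compound 2 `Cc1ccc(CNc2nc3ccc([N+](=O)[O-])cc3nc2NCCCN(C)C)cc1` gives 15.8 ug/mL

Compound 2 stands at the higher of the two numbers in an ADME assay on HEK293 cells (Homo sapiens) for cytotoxicity, read by MTT assay, with a stated time of 24 h (a lower number here means a stronger inhibitor, a higher number a weaker inhibitor), though its gap to compound 1 lies within the scatter, so the two cannot be ordered. Compound 3 `CN(C)CCCNc1nc2cc([N+](=O)[O-])ccc2nc1NCc1cc(F)cc(C(F)(F)F)c1` has not yet been measured. It arises from compound 2 by one change: 3-fluoro-5-(trifluoromethyl)phenyl in place of 4-methylphenyl on a saturated chain carbon bound to a nitrogen on an aromatic ring. Because compound 1, which also carries a trifluoromethyl on its ring, gives 9.73 ug/mL, compound 3 is expected to land near that value or somewhat lower. The expected step of a 1.8-fold lower number from compound 2 to compound 3 (0.24 log units; within the scatter) is small, at the edge of the scatter. Compound 3 is estimated at 9 ug/mL, with a range from 4 ug/mL to 20 ug/mL.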

Compound 3, half-maximal inhibitory concentration: 2.67 ug/mL
Estimate against measurement, compound 3: 3.4-fold (0.53 log units) above, and the stated range ends above it.
By their numbers in this assay, from the lowest: compound 3; then compounds 1 and 2 (each within the scatter of the next).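

In this assay, among these compounds, putting 3-fluoro-5-(trifluoromethyl)phenyl in place of 4-methylphenyl gives a 5.9-fold lower number from compound 2 to compound 3 (0.77 log units; beyond the scatter) and thus the first step here that clears the scatter. The group on this saturated chain carbon can therefore shift the number, which compound 1 and compound 2 alone could not show. No measurement here accounts for the size of the step. Going by these compounds, the change brings in fluorine and trifluoromethyl together, so the share of each stays open. A 3-fluorophenyl or a 3-(trifluoromethyl)phenyl at this place would separate them.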